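From ethyl to ethoxy on a nitroimidazole chain

The compounds below may be only part of what the source reports. "The series", "measured", "known", "first", "only" and "open" are said of these compounds alone.

Measured in a functional assay on A549 cells (Homo sapiens) for inhibition, read by sulforhodamine B assay, with a stated time of 72 h; a higher number here means a weaker inhibitor, a lower number a stronger inhibitor:
compound 1 `C#Cc1cccc(Nc2ncnc3cc(OCCOCCn4ccnc4[N+](=O)[O-])c(OC)cc23)c1`: 6430 nM
compound 2 `COc1cc2c(Nc3cccc(Br)c3)ncnc2cc1OCCCn1ccnc1[N+](=O)[O-]`: 7830 nM
compound 3 `COc1cc2c(Nc3cccc(Br)c3)ncnc2cc1OCCCCn1ccnc1[N+](=O)[O-]`: 1970 nM

Of these three, compound 3 has the lowest number, and its gaps to the other two lie beyond the scatter. Compound 4 `COc1cc2c(Nc3cccc(Br)c3)ncnc2cc1OCCOCCn1ccnc1[N+](=O)[O-]` differs from compound 3 by a single change: 2-(2-nitro-1H-imidazol-1-yl)ethoxy in place of 2-(2-nitro-1H-imidazol-1-yl)ethyl on a saturated chain carbon, two bonds along the chain from an oxygen on an aromatic ring. Within the data shown here, the only measured step that bears on this chain is a 4.0-fold lower number from compound 2 to compound 3 (0.60 log units; beyond the scatter), and it involves no ethoxy group, so it guides only loosely. Compound 1 carries the same 2-(2-nitro-1H-imidazol-1-yl)ethoxy group but differs elsewhere, and it gives 6430 nM. A modest rise in this assay is therefore expected, an estimated 2.0-fold higher number from compound 3 to compound 4 (0.31 log units; beyond the scatter). The expected value for compound 4 is 4000 nM, within an estimated range of 1500 nM to 10000 nM.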

Compound 4, half-maximal inhibitory concentration: 10100 nM
Estimate against measurement, compound 4: 2.5-fold (0.40 log units) below; the measured number lies above the stated range.
By their numbers in this assay, from the lowest: compound 3; then compounds 1, 2 and 4 (each within the scatter of the next).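

In this assay, a 5.1-fold higher number from compound 3 to compound 4 (0.71 log units; beyond the scatter) shows that the lower number gained by lengthening the all-carbon chain is lost once the 2-(2-nitro-1H-imidazol-1-yl)ethoxy group enters. That chain sits level with the shorter one, a 1.3-fold higher number from compound 2 to compound 4 (0.11 log units; within the scatter), and bromo and ethynyl cannot be told apart on this chain, a 1.6-fold higher number from compound 1 to compound 4 (0.20 log units; within the scatter). Nothing measured here explains the loss. Still open, from the compounds shown here alone, is whether a longer all-carbon chain would lower the number further, and whether an amine in place of the chain oxygen would restore it.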